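The source may report more compounds than this note shows. Statements on the series, on what has been measured and on what is new or still open speak of the compounds shown alone.

Working notes on the series. Compound 1 `CCCCCCCCCCc1cc2cn(COCCO)c(O)nc-2n1` carries a decyl chain on its core. In a functional assay on HEL cells (Homo sapiens), read by microscopy (on this read-out lower numbers stand for higher toxicity in this test and higher numbers for lower toxicity in this test), compound 1 gives 80000 nM. Compound 3 `CCCCCCCCCCCc1cc2cn(COCCO)c(=O)nc2o1` carries an undecyl chain on another core, and in this assay compound 3 gives 80000 nM, so compound 1 stands level with compound 3 at the digits shown, within the scatter. Compound 2 `CCCCCCC#Cc1cc2cn(COCCO)c(=O)nc2o1` reaches only a limit in this assay, and > 200000 nM for compound 2 is that limit of the assay, not a number. Among the three values shown, one sits at the limit of > 200000 nM in this assay, at which 1 of the 3 values shown sits.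

Compound 4 `CCCCCCCCCCCc1cc2cn(COCCO)c(O)nc-2n1` is compound 1 with methyl in place of hydrogen on a saturated chain carbon, ten or more bonds along the chain from an aromatic carbon. Among the compounds with values here, no step between measured compounds on this change within one core is available. Compound 4 shares its chain with compound 3, which sits on another core, and compound 3 gives 80000 nM, level with compound 1. In this assay the step of no change at the digits printed from compound 1 to compound 4 (within the scatter) is expected to be none beyond the scatter. Compound 4 is therefore expected to give 80000 nM in this assay, with a range from 40000 nM to 160000 nM.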

Compound 4, minimum cytotoxic concentration: 80000 nM
Beside the measured number, compound 4's estimate shows no gap at the digits printed; the range from low to high includes it.
By their numbers in this assay, from the lowest: compounds 1, 3 and 4 (each within the scatter of the next). At a limit, above all of these: compound 2.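

In this assay, the series now has its first step within one core: no change at the digits printed from compound 1 to compound 4 (within the scatter). The change is methyl in place of hydrogen on a saturated chain carbon, ten or more bonds along the chain from an aromatic carbon, so on the core of compound 1 the decyl and undecyl chains read alike, which the earlier comparison across two cores could not show. No measured property shown here bears on this step.

Going by these compounds, whether a much shorter chain such as hexyl, a longer chain such as dodecyl, or an amine or carboxylic acid at the chain end would read the same in this assay stays open. Compound 2 gives > 200000 nM, a limit of the assay and not a number, and the compounds shown do not tell how its chain would read on the core of compound 1.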